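The source may hold more compounds than are shown below. What is called first, only, known or untested is meant among the compounds shown, and "the series" means these compounds.

Measured in a functional assay on PC-3M cells (Homo sapiens) for antiproliferative activity, read by microscopy, with a stated time of 24 h; a higher number here means a weaker inhibitor, a lower number a stronger inhibitor:
- compound 1 `O[C@H]1CC[C@H](Nc2ncnc3c2c(-c2ccccc2)c(-c2ccccc2)n3Cc2ccccc2)CC1`: > 20000 nM, a limit of the assay
- compound 2 `COc1ccc(-c2c(-c3ccc(OC)cc3)n(Cc3ccccc3)c3ncn([C@H]4CC[C@H](OC)CC4)c(=N)c23)cc1`: > 20000 nM, a limit of the assay
- compound 3 `COc1ccc(Cn2c(-c3ccccc3)c(-c3ccccc3)c3c(=N)n([C@H]4CC[C@H](O)CC4)cnc32)cc1`: 160 nM; 158 nM (2 entries)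

Compound 2 gives only the limit > 20000 nM, so no exact number fixes its place. Compound 4 `COc1ccc(-c2c(-c3ccc(OC)cc3)n(Cc3ccccc3)c3ncn([C@@H]4CCCC[C@H]4O)c(=N)c23)cc1` differs from it at one site: 2-hydroxycyclohexyl in place of 4-methoxycyclohexyl on an aromatic nitrogen. Here 2-hydroxycyclohexyl replaces 4-methoxycyclohexyl on an aromatic nitrogen.

A hydroxyl on the cyclohexyl ring occurs in compound 3, which gives 160 nM; 158 nM (2 entries). Compound 1 also carries one, yet it gives only the limit > 20000 nM. A moderate move towards stronger inhibition in this assay is therefore expected, though with little confidence. The expected step is an at least 3.3-fold lower number from compound 2 to compound 4 (0.52 log units; beyond the scatter). For compound 4 the estimated value is 6000 nM, with an expected range of 800 nM to 20000 nM.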

Compound 4, half-maximal inhibitory concentration: > 20000 nM
Compound 4 ended at the assay's limit; the forecaster's own chance of this, stated with the estimate: 40%; middle value at least 3.3-fold (0.52 log units) away from the limit.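

Compound 2 and compound 4 both end at a limit rather than a number, so the step between them cannot be read. The compounds shown leave open whether 2-hydroxycyclohexyl in place of 4-methoxycyclohexyl changes inhibition at all.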